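Swapping a Bulky Urea Tail for a Small Sulfonyl

A few compounds are considered here, and "the series" means these few. Any claim that something is new, unique, unknown or untested is made for them only; others in the source may bear on it.

Compound 1 `Cn1nc(COc2cc(F)cc(F)c2)c2c1CCN(C(=O)Nc1ccc(Cl)cc1)C2` carries a urea whose far end is a 4-chlorophenyl group; in an assay on cells for inhibition of Pendrin (Mus musculus), read by fluorescence, with a stated time of 10 min (on this read-out higher numbers stand for weaker inhibition and lower numbers for stronger inhibition), compound 1 gives 3100 nM. Compound 2 `Cn1nc(COc2cc(F)cc(F)c2)c2c1CCN(C(=O)NC1CCCCC1)C2` keeps the same core but puts a cyclohexyl ring where the 4-chlorophenyl was. In this assay compound 2 reaches only the limit of the assay, > 10000 nM, which is a limit and not a measured number. This places compound 2 at the weaker end of the two values shown, since an at least 3.2-fold higher number from compound 1 to compound 2 (0.50 log units; beyond the scatter). Compound 3 `Cn1nc(COc2cc(F)cc(F)c2)c2c1CCN(S(C)(=O)=O)C2` goes further: methylsulfonyl in place of cyclohexylcarbamoyl on an amine nitrogen in a ring. Going by the values given here, the only measured step that bears on this change is an at least 3.2-fold higher number from compound 1 to compound 2 (0.50 log units; beyond the scatter), and it runs toward weaker inhibition; moreover compound 2 already sits at the limit of > 10000 nM in this assay, at which 1 of the 2 values shown sits, so no larger change can be resolved from that side. With compound 3 the urea is gone altogether, and nothing measured here shows a small group recovering strength. The expectation is therefore that compound 3 lands at or past the limit again, at an estimated 15000 nM in this assay, within roughly 5000 nM to 50000 nM. The expected step that the limit leaves unreadable from compound 2 to compound 3 is thus essentially none that the assay could resolve.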

Compound 3, half-maximal inhibitory concentration: > 10000 nM
Compound 3: a limit, no number; the forecaster's own chance of this, stated with the estimate: 70%; the middle value does not contradict the limit.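

On this amine nitrogen in a ring, methylsulfonyl in place of (4-chlorophenyl)carbamoyl gives an at least 3.2-fold higher number from compound 1 to compound 3 (0.50 log units; beyond the scatter), so in this assay compound 1 now falls ahead of two quite different groups rather than one. For compound 3 the reading is > 10000 nM, which is a limit of the assay and not a number. Only compound 1 therefore gives a measured value, and the step from compound 2 to compound 3 cannot be read, which means the cyclohexyl urea and the methylsulfonyl group cannot be ranked against each other: the limit of > 10000 nM in this assay, at which 2 of the 3 values shown sit.

Going by these compounds, what remains open is which part of the (4-chlorophenyl)carbamoyl group goes with the measurable inhibition of compound 1: the aromatic ring, the urea link, or the two together. A phenylsulfonyl group on the same amine nitrogen would pair that kind of aromatic ring with the sulfonyl link in place of the urea, and so would bear directly on this question.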